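The source may report more compounds than this note shows. Statements on the series, on what has been measured and on what is new or still open speak of the compounds shown alone.

In a physicochemical assay for lipophilicity, read by HPLC, at pH 7.4 (a higher number here means a more lipophilic compound, a lower number a more polar compound), compound 1 (`CNCc1cn(S(=O)(=O)c2ccoc2)c(-c2cccnc2F)c1F`) gives 0.45 while compound 2 (`CNCc1cn(S(=O)(=O)c2ccc(F)cn2)c(-c2cccnc2F)c1F`) gives 0.42 and compound 3 (`CNCc1cn(S(=O)(=O)c2cccnc2C)c(-c2cccnc2F)c1F`) gives 0.48 on the same scale, so compound 3 stands within the scatter of both others. Compound 4 (`CNCc1cn(S(=O)(=O)c2ccc(C)nc2)c(-c2cccnc2F)c1F`) is still unmeasured and differs from compound 3 thus: 6-methylpyridin-3-yl in place of 2-methylpyridin-3-yl on a sulfonyl sulfur with 6-methylpyridin-3-yl in place of 2-methylpyridin-3-yl on a sulfonyl sulfur. Among the compounds with values here, no measured pair isolates this swap. The nearest evidence is a number 0.03 log units lower from compound 1 to compound 2 (within the scatter) and a number 0.03 log units higher from compound 1 to compound 3 (within the scatter) and a number 0.06 log units higher from compound 2 to compound 3 (within the scatter) on that same sulfur, so no step beyond the scatter is expected in this assay here. The expected step is a number 0.02 log units higher from compound 3 to compound 4 (within the scatter) and stays within the scatter. For compound 4 the estimated value is 0.5 with an expected range from 0.2 to 0.8 pending measurement.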

Compound 4, distribution coefficient: 0.62
For compound 4 the middle estimate is 0.12 log units below the measured one; low and high end bracket the measured number.
By their numbers in this assay, from the lowest: compounds 2, 1, 3 and 4 (each within the scatter of the next).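

In this assay putting 6-methylpyridin-3-yl in place of 2-methylpyridin-3-yl, the same atoms joined differently, gives a number 0.14 log units higher from compound 3 to compound 4 (within the scatter) and so extends the sulfonyl sulfur series to a swap that leaves the atoms unchanged. With a number 0.20 log units higher from compound 2 to compound 4 (within the scatter) and a number 0.17 log units higher from compound 1 to compound 4 (within the scatter) also printed as within the scatter, the furan-3-yl, 5-fluoropyridin-2-yl and 6-methylpyridin-3-yl groups show no separation on this sulfur. Nothing shown accounts for these readings. Open, from the compounds shown here alone, is whether an amine or a carboxylic acid on the aryl ring at this sulfur would give a step beyond the scatter.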